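Series notes: hydrogen in place of carboxymethyl

The source may report more compounds than this note shows. Statements on the series, on what has been measured and on what is new or still open speak of the compounds shown alone.

Measured compounds:
compound 1 `C[C@H]1N=C2C[C@H]3C[C@H](C3(C)C)[C@@]2(C)OC1=O`: 27000 nM
compound 2 `CC1(C)[C@@H]2CC3=N[C@@H](CCC(=O)O)C(=O)O[C@@]3(C)[C@H]1C2`: 36000 nM

Both were run in a functional assay on EL4 cells (Mus musculus) for antiproliferative activity, read by sulforhodamine B assay, with a stated time of 48 h; a higher number here means a weaker inhibitor, a lower number a stronger inhibitor. Compound 2 carries the higher of the two numbers, but its gap to compound 1 is within the scatter, so no order between them can be read from these two values.

Compound 3 `C[C@@H]1N=C2C[C@@H]3C[C@@H](C3(C)C)[C@]2(C)OC1=O` has not yet been measured. Relative to compound 2 the change is hydrogen in place of carboxymethyl on a saturated chain carbon bound to a saturated ring carbon. Among the measured compounds shown here, no step between measured compounds covers this kind of change, so there is nothing in the data to size it from. With compound 2 sitting at 36000 nM and no shown step pointing either way, the working expectation is no change beyond the scatter, a 1.2-fold lower number from compound 2 to compound 3 (0.08 log units; within the scatter), in this assay.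

For compound 3 the estimated value in this assay is 30000 nM, with a range of 10000 nM to 90000 nM.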

Compound 3, half-maximal inhibitory concentration: 145000 nM
Estimate against measurement, compound 3: 4.8-fold (0.68 log units) below; measured number above the stated range.
By their numbers in this assay, from the lowest: compounds 1 and 2 (each within the scatter of the next); then compound 3.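

Among the compounds shown here, the position on the saturated chain carbon turns out to matter: the 2-carboxyethyl to methyl swap, read as hydrogen in place of carboxymethyl, gives a 4.0-fold higher number from compound 2 to compound 3 (0.61 log units; beyond the scatter) in this assay, the first sized step for this change. Configuration matters as well, with a 5.4-fold higher number from compound 1 to compound 3 (0.73 log units; beyond the scatter), a step of similar size to the chain change. The second step can be assigned to configuration alone, since nothing else separates the pair: the fact that compounds 1 and 3 differ only in the configuration as drawn.

Going by these compounds, what remains open is whether the carboxylic acid end or simply the length of the chain carries the difference between compound 2 and compound 3, which a plain propyl chain or a primary amine at the chain end would help to separate. The compounds shown also leave open how an ethyl ester at this position would read in this assay.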